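Swapping fluoro for trifluoromethyl on the amino-bearing ring

The source may report more compounds than this note shows. Statements on the series, on what has been measured and on what is new or still open speak of the compounds shown alone.

Compound 3 `O=C(/C=C\Nc1ccc(F)cc1)c1cn(-c2ccccc2)nc1-c1ccc(F)cc1` gives 6500 nM in a functional assay on HT-29 cells (Homo sapiens) for antiproliferative activity, read by MTT assay, with a stated time of 48 h (a lower number here means a stronger inhibitor, a higher number a weaker inhibitor), the lowest of the two numbers available, though compound 1 `O=C(/C=C\Nc1ccc(F)cc1)c1cn(-c2ccccc2)nc1-c1ccccc1` sits within the scatter of it at 6870 nM. Compound 2 `O=C(/C=C\Nc1ccc(C(F)(F)F)cc1)c1cn(-c2ccccc2)nc1-c1ccccc1` reached only the limit > 50000 nM in this assay. Compound 4 `O=C(/C=C\Nc1ccc(C(F)(F)F)cc1)c1cn(-c2ccccc2)nc1-c1ccc(F)cc1` differs from compound 3 by trifluoromethyl in place of fluoro on an aromatic carbon, turning a (4-fluorophenyl)amino group into a (4-(trifluoromethyl)phenyl)amino group. The same exchange occurs once among the measured pairs, where it gave an at least 7.2-fold higher number from compound 1 to compound 2 (0.86 log units; beyond the scatter), ending at a limit (the limit of > 50000 nM in this assay, at which 1 of the 3 values shown sits). A weakening of at least modest size is therefore expected for compound 4, with a 7.7-fold higher number from compound 3 to compound 4 (0.89 log units; beyond the scatter). Compound 4 is estimated at 50000 nM, within 20000 nM to 150000 nM, and may well be reported only as a limit.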

Compound 4, half-maximal inhibitory concentration: > 50000 nM
Compound 4: only a limit was reported; the forecaster's own chance of this, stated with the estimate: 70%; the middle value lies on the limit itself.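

Trifluoromethyl in place of fluoro now gives an at least 7.6-fold higher number from compound 3 to compound 4 (0.88 log units; beyond the scatter) in this assay, so the loss no longer rests on a single pair of compounds. It appears with and without the fluoro on the other aryl group: the same change on two cores in this assay, an at least 7.2-fold higher number (0.86 log units; beyond the scatter) from compound 1 to compound 2 and an at least 7.6-fold higher number (0.88 log units; beyond the scatter) from compound 3 to compound 4; the limit leaves it open whether they differ Both trifluoromethyl compounds end at a limit, so the step between compound 2 and compound 4 cannot be read: the limit of > 50000 nM in this assay, at which 2 of the 4 values shown sit.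

From the compounds shown here alone, how much weaker compound 2 and compound 4 truly are remains unknown. Also open, going by these compounds, is whether chloro, methyl or methoxy on this aromatic carbon would keep the activity seen with fluoro.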